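Swapping Trimethylphenyl for Trichlorophenyl on an Aromatic Nitrogen

The compounds below may be only part of what the source reports. "The series", "measured", "known", "first", "only" and "open" are said of these compounds alone.

Compound 1 `N#CC1=C(N)Oc2c(N)cc3nc4ccccc4nc3c2C12C(=O)N(Cc1cnnn1-c1ccccc1Br)c1ccccc12`: 29200 nM in an ADME assay on L02 cells (Homo sapiens) for antiproliferative activity, read by MTT assay, with a stated time of 48 h; on this read-out lower numbers stand for stronger inhibition and higher numbers for weaker inhibition
Compound 2 `N#CC1=C(N)Oc2c(N)cc3nc4ccccc4nc3c2C12C(=O)N(Cc1cnnn1-c1cccc(C(F)(F)F)c1)c1ccccc12`: 38100 nM in this assay
Compound 3 `Cc1cc(C)c(-n2nncc2CN2C(=O)C3(C(C#N)=C(N)Oc4c(N)cc5nc6ccccc6nc5c43)c3ccccc32)c(C)c1`: > 50000 nM in this assay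

The three compounds share one core and differ only in the aryl group sitting on an aromatic nitrogen of a five-membered aromatic ring with 3 nitrogen. For compound 3 the reading in this assay is a limit of the assay, not a number, so compound 3 stands at the weak end of what was measured; this is the limit of > 50000 nM in this assay, at which 1 of the 3 values shown sits. The steps leading to it were an at least 1.7-fold higher number from compound 1 to compound 3 (0.23 log units; that floor lies within the scatter) and an at least 1.3-fold higher number from compound 2 to compound 3 (0.11 log units; that floor lies within the scatter), neither clearly beyond the scatter.

Compound 4 `N#CC1=C(N)Oc2c(N)cc3nc4ccccc4nc3c2C12C(=O)N(Cc1cnnn1-c1c(Cl)cc(Cl)cc1Cl)c1ccccc12` is not yet measured. It differs from compound 3 by 2,4,6-trichlorophenyl in place of 2,4,6-trimethylphenyl on an aromatic nitrogen. Within the data shown here, no measured step here exchanges one 2,4,6-trisubstituted phenyl for another, so the only guide is that compound 3 reached the limit. For compound 4 the expectation is a step that the limit leaves unreadable from compound 3 to compound 4, that is, no step beyond the scatter. Compound 4 is therefore estimated at 55000 nM in this assay, with a likely range from 25000 nM to 120000 nM, and a good chance that only a limit is reported again.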

Compound 4, half-maximal inhibitory concentration: > 50000 nM
Compound 4: no number, only a limit (the forecaster's own chance of this, stated with the estimate: 60%); the middle value does not contradict the limit.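

With 2,4,6-trichlorophenyl on the aromatic nitrogen, compound 4 gives a limit of the assay rather than a number, the same limit as compound 3: the limit of > 50000 nM in this assay, at which 2 of the 4 values shown sit. The step between these two limits cannot be read, so exchanging the three methyl groups for three chlorine atoms gives no measurable difference in this assay. The steps that can be read are an at least 1.3-fold higher number from compound 2 to compound 4 (0.11 log units; that floor lies within the scatter) and an at least 1.7-fold higher number from compound 1 to compound 4 (0.23 log units; that floor lies within the scatter), so the new group does not clearly separate compound 4 from either compound with a numerical value.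

Going by these compounds, how far compound 3 and compound 4 lie beyond their shared limit remains open. So does what this nitrogen would give with a plain phenyl ring, or with a phenyl ring carrying an amine or a carboxylic acid.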